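Dichlorophenyl to Dimethoxyphenyl on a Weak Growth Inhibitor

The source may report more compounds than this note shows. Statements on the series, on what has been measured and on what is new or still open speak of the compounds shown alone.

Three compounds built on one shared core were tested in a functional assay on CAKI-1 cells (Homo sapiens) for inhibition, read by sulforhodamine B assay, with a stated time of 48 h; a lower number here means a stronger inhibitor of growth, a higher number a weaker inhibitor of growth. Compound 1 `Nc1cc(N)c2nc(-c3ccccc3)c(Oc3ccc(Cl)c(Cl)c3)nc2c1` reaches only the limit of the assay, < 100000 nM. Compound 2 `CCOC(=O)[C@H](CCC(=O)O)NC(=O)c1ccc(CNc2nc3cc(N)cc(N)c3nc2-c2ccccc2)cc1` likewise gives only a limit, < 100000 nM. For the measured compounds named here, compound 3 `Nc1cc(N)c2nc(-c3ccccc3)c(NCc3ccc(Cl)c(Cl)c3)nc2c1` is the single member with a real number: in this assay compound 3 gives 52500 nM. Going by the values given here, compound 3 therefore stands as the only measured value, while the two others sit at the limit of < 100000 nM in this assay, at which 2 of the 3 values shown sit.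

Compound 4 `COc1ccc(CNc2nc3cc(N)cc(N)c3nc2-c2ccccc2)cc1OC` has not been measured. It differs from compound 3 in one place: 3,4-dimethoxyphenyl in place of 3,4-dichlorophenyl on a saturated chain carbon bound to a nitrogen on an aromatic ring. Among the compounds with values here, no step between measured compounds is available to tell how large such a change is here, so the expectation rests on compound 3 alone. The step from compound 3 to compound 4 is expected to be a 1.3-fold higher number from compound 3 to compound 4 (0.12 log units; within the scatter), leaning toward weaker inhibition but not beyond the usual scatter. Compound 4 is thus expected to give about 70000 nM, with a likely range from 25000 nM to 150000 nM, and it may well be reported only as a limit.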

Compound 4, concentration for total growth inhibition: 24500 nM
Beside the measured number, compound 4's estimate is 2.9-fold (0.46 log units) above it, outside the stated range (below it).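

In this assay, this position on a saturated chain carbon bound to a nitrogen on an aromatic ring now has a measured change: 3,4-dimethoxyphenyl in place of 3,4-dichlorophenyl gives a 2.1-fold lower number from compound 3 to compound 4 (0.33 log units; beyond the scatter). The chlorine atoms are therefore not required for the growth inhibition seen with compound 3, and the substituents on this ring can shift the result, although the step is modest and compound 4 remains a weak inhibitor. Nothing shown gives a cause for this step.

From the compounds shown here alone, it remains open whether a single methoxy group, an unsubstituted phenyl or a ring bearing a carboxylic acid would lower the number further, and whether a longer chain to the ring would help or hurt. A single step also cannot show whether the same swap would have a similar effect on another core.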